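A few compounds are considered here, and "the series" means these few. Any claim that something is new, unique, unknown or untested is made for them only; others in the source may bear on it.

Of the compounds shown here, three sharing one core have been measured in an assay on isolated protein for inhibition of DNA topoisomerase 1 (Homo sapiens), with a stated time of 30 min, tested at 100 uM; a higher number here means a stronger effect of the compound at the concentration tested, a lower number a weaker effect. Compound 1 `Oc1cccc(-c2cc(-c3ccccc3)nc(-c3cccs3)c2)c1` gives 9.1%. Compound 2 `Oc1cccc(-c2cc(-c3ccccc3)nc(-c3ccsc3)c2)c1` gives 6.9%. Compound 3 `Oc1cccc(-c2cc(-c3ccccc3)nc(-c3ccco3)c2)c1` gives 48.8%, the highest of the three numbers, and its lead over both of the other two is beyond the scatter: a number 39.7 percentage points higher from compound 1 to compound 3 (beyond the scatter) and a number 41.9 percentage points higher from compound 2 to compound 3 (beyond the scatter). Between the two thiophene compounds there was no real difference, since a number 2.2 percentage points lower from compound 1 to compound 2 (within the scatter).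

The next compound, compound 4 `Oc1cccc(-c2cc(-c3ccccc3)nc(-c3ccccn3)c2)c1`, is built from compound 3 by a change on the same aromatic carbon: pyridin-2-yl in place of furan-2-yl on an aromatic carbon

Going by the values given here, two measured steps bear on this position, and both show that swapping the five-membered ring there can move the number a great deal: the step from thiophen-2-yl to furan-2-yl and the step from thiophen-3-yl to furan-2-yl were each large gains. No measured step involves a six-membered ring at this position, so the direction for pyridin-2-yl is not directly shown. Given that only furan-2-yl gave the highest of the three numbers, while both thiophene rings stood beyond the scatter below it, compound 4 is expected to fall below compound 3, with a number 28.8 percentage points lower from compound 3 to compound 4 (beyond the scatter) as the estimated step. Compound 4 is therefore estimated at 20%, within a range from 3% to 50%.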

Compound 4, a percentage reported as inhibition, at one concentration (the size of the read-out at that concentration, not a potency): 10.8%
For compound 4 the middle estimate is 9.2 percentage points above the measured one; the range from low to high includes it.
By their numbers in this assay, from the lowest: compounds 2, 1 and 4 (each within the scatter of the next); then compound 3.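

Pyridin-2-yl, the first six-membered ring seen at this position, does not keep the number that furan-2-yl gave (a number 38 percentage points lower from compound 3 to compound 4 (beyond the scatter)). It stands level with both thiophene compounds (a number 3.9 percentage points higher from compound 2 to compound 4 (within the scatter) and a number 1.7 percentage points higher from compound 1 to compound 4 (within the scatter)), so ring size alone does not sort these compounds: the six-membered pyridin-2-yl groups with the five-membered thiophene rings, and among the four rings shown only furan-2-yl stands apart. Nothing available here explains why furan-2-yl differs from the other three rings.

The compounds shown leave open whether furan-3-yl would keep the number of furan-2-yl, and whether pyridin-3-yl or pyridin-4-yl would stand apart from pyridin-2-yl, as the two thiophene rings did not from each other. They also leave open what a group without a ring on this same aromatic carbon, such as an amine or a short alkyl chain, would do to the number, and whether furan-2-yl would keep its lead if the 3-hydroxyphenyl or phenyl group of the shared core were changed.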